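Removing the Octanoyl Group from the Ring Nitrogen

This account rests on a few compounds, and the source may have more. Where it says the series, first, only, none or still open, it means among the compounds named here.

Compound 3 `CCCCCCCCC(=O)N1c2ccccc2CCC1C(=O)Nc1cc(C(F)(F)F)cc(C(F)(F)F)c1` gives 4520 nM in a functional assay on ACHN cells (Homo sapiens) for cytotoxicity, read by sulforhodamine B assay, with a stated time of 72 h (a higher number here means a weaker inhibitor of growth, a lower number a stronger inhibitor of growth), the highest number among the three measured compounds; it sits within the scatter of compound 2 `O=C(Nc1cc(C(F)(F)F)cc(C(F)(F)F)c1)C1CCc2ccccc2N1C(=O)c1ccccc1`, which gives 2920 nM, and is clearly separated from compound 1 `O=C(Nc1cc(C(F)(F)F)cc(C(F)(F)F)c1)C1CCc2ccccc2N1C(=O)c1cccc(Cl)c1`, which gives 813 nM. Compound 4 `O=C(Nc1cc(C(F)(F)F)cc(C(F)(F)F)c1)C1CCc2ccccc2N1` differs from compound 3 in one place: hydrogen in place of octylcarbonyl on a nitrogen on an aromatic ring in a ring. Within the data shown here, no measured step strips that group away entirely; the closest are the exchanges of it, where a 1.5-fold higher number from compound 2 to compound 3 (0.19 log units; within the scatter) and a 5.6-fold higher number from compound 1 to compound 3 (0.75 log units; beyond the scatter), while a 3.6-fold higher number from compound 1 to compound 2 (0.56 log units; beyond the scatter). Because a 5.6-fold higher number from compound 1 to compound 3 (0.75 log units; beyond the scatter) and a 1.5-fold higher number from compound 2 to compound 3 (0.19 log units; within the scatter) moved the number only modestly, a modest further rise is expected for compound 4, that is a 1.8-fold higher number from compound 3 to compound 4 (0.25 log units; within the scatter). The estimate for compound 4 is 8000 nM, with a range from 2500 nM to 25000 nM.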

Compound 4, concentration for 50% growth inhibition: 8190 nM
For compound 4 the middle estimate is 1.0-fold (0.01 log units) below the measured one; low and high end bracket the measured number.
By their numbers in this assay, from the lowest: compound 1; then compounds 2, 3 and 4 (each within the scatter of the next, the first and the last beyond it).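

With hydrogen on the ring nitrogen, compound 4 provides a plain reference for the groups placed there in this assay. Measured against it, octylcarbonyl stays within the scatter (a 1.8-fold higher number from compound 3 to compound 4 (0.26 log units; within the scatter)), whereas benzoyl gives a clear gap (a 2.8-fold higher number from compound 2 to compound 4 (0.45 log units; beyond the scatter)) and (3-chlorophenyl)carbonyl the widest one (a 10-fold higher number from compound 1 to compound 4 (1.00 log units; beyond the scatter)). Nothing available here explains these differences. Still open, as far as these compounds go, is how a methyl or a methylsulfonyl group on this nitrogen would compare, and whether a fluoro or methoxy group could replace the chloro.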